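The source may report more compounds than this note shows. Statements on the series, on what has been measured and on what is new or still open speak of the compounds shown alone.

Compound 2 (`COC(=O)Nc1cc(-c2ccc(OC[C@@](C)(N)CC(C)C)c(C)c2)ccn1`) gives 98% in an ADME assay on microsomes from liver (Homo sapiens) for metabolic stability, read by LC-MS, using NADPH, with a stated time of 10 min, tested at 0.5 uM (a higher number here means that more of the compound is left, a lower number that less of the compound is left), and stands level, within the scatter, with compound 1 (`CC(=O)Nc1cc(-c2cc(F)c(OC[C@@H](N)CC(C)C)c(F)c2)ccn1`) at 90% on this read-out. Compound 3 (`COC(=O)Nc1cc(-c2ccc(OC[C@@](C)(N)CC(C)C)c(F)c2)ccn1`) gives 82% in this assay and is set apart from compound 2 by a gap beyond the scatter. Within the data shown here, that gap is the only measured step, a number 16 percentage points lower from compound 2 to compound 3 (beyond the scatter) and it is modest in size.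

Compound 4 (`COC(=O)Nc1cc(-c2ccc(OC[C@@](C)(N)CC(C)C)c(C)c2C)ccn1`) keeps the structure of compound 2 except at one place: methyl in place of hydrogen on an aromatic carbon with methyl in place of hydrogen on an aromatic carbon, ortho to a methyl group and ortho to a large group. Among the measured compounds shown here, no measured step adds a group at that carbon, so the data give no direct guide. The step to compound 3 changes the existing methyl instead and bears only loosely, showing that a single small swap on this ring can produce a modest shift. With compound 2 at 98% there is little room upward, and a small loss seems more likely than a gain. The expected change is a number 4 percentage points lower from compound 2 to compound 4 (within the scatter) and no step beyond the scatter is anticipated. For compound 4 the estimated value is 94% with an expected range from 82% to 100% in this measurement.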

Compound 4, percent of the compound remaining: 93%
Compound 4: the middle estimate sits 1 percentage points above what was measured, and the stated range covers the measured number.
By their numbers in this assay, from the lowest: compounds 3, 1, 4 and 2 (each within the scatter of the next, the first and the last beyond it).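

In this assay, placing a methyl on the aromatic carbon ortho to a large group and ortho to a methyl group gives a number 5 percentage points lower from compound 2 to compound 4 (within the scatter), so at this carbon the added group brings no shift that can be told from the scatter. The earlier compounds shown here offered only a swap of the existing methyl for fluoro, a number 16 percentage points lower from compound 2 to compound 3 (beyond the scatter), and that step said nothing about whether the carbon bearing hydrogen could take a substituent without a loss beyond the scatter. Nothing shown here gives a reason for either result.

Methyl is the only group seen at this carbon, so the compounds shown leave open how a fluoro, a methoxy, an ethyl or an amine placed there would read in this assay. Also open, from the compounds shown here alone, is whether the same added methyl would read the same way on compound 3, where fluoro stands in place of the existing methyl, and whether the result holds on the core of compound 1, which carries an acetamide rather than a methyl carbamate.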